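The source may hold more compounds than are shown below. What is called first, only, known or untested is meant among the compounds shown, and "the series" means these compounds.

Compound 1 `CN1CCN(c2ccc(C3=NN(C(=O)c4ccc(F)cc4)C(c4ccc(N(C)C)cc4)C3)cc2)CC1` and compound 2 `CN(C)c1ccc(C2CC(c3ccc(-n4cncn4)cc3)=NN2C(=O)c2ccc(F)cc2)cc1` share one core and differ only in the group on one aromatic carbon. In a functional assay on MDA-MB-231 cells (Homo sapiens) for inhibition, read by sulforhodamine B assay, tested at 10 uM (on this read-out higher numbers stand for more inhibition at the one concentration tested (going by the name of the read-out) and lower numbers for less inhibition), compound 1 gives 3.5%, and compound 2 gives 12.5%. For the measured compounds named here, the single measured step, a number 9 percentage points higher from compound 1 to compound 2 (within the scatter), came with 1H-1,2,4-triazol-1-yl in place of 4-methylpiperazin-1-yl on an aromatic carbon. Compound 2 thus holds the higher of the two numbers recorded, but compound 1 sits within the scatter of it, so the pair cannot be separated on this read-out. Compound 3 `CN(C)c1ccc(C2CC(c3ccc(-n4cncn4)cc3)=NN2S(=O)(=O)c2ccc(F)cc2)cc1` keeps the core of compound 2 and differs in one place: (4-fluorophenyl)sulfonyl in place of (4-fluorophenyl)carbonyl on an amine nitrogen in a ring. Going by the values given here, no measured step touches the amine nitrogen in the ring; the only one recorded concerns an aromatic carbon and offers no guide here, while both measured numbers lie near the bottom of the scale. Compound 3 is therefore expected to remain in that low region, with an estimated step of a number 0.5 percentage points lower from compound 2 to compound 3 (within the scatter) that does not exceed the scatter. The estimate for compound 3 in this assay is 12%, with a range from 0% to 35%.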

Compound 3, a percentage reported as inhibition, at one concentration (the size of the read-out at that concentration, not a potency): 12.1%
Beside the measured number, compound 3's estimate is 0.1 percentage points below it; the measured number falls inside the stated range.
By their numbers in this assay, from the lowest: compounds 1, 3 and 2 (each within the scatter of the next).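

In this assay, for the compounds shown here, the exchange of (4-fluorophenyl)carbonyl for (4-fluorophenyl)sulfonyl on the amine nitrogen in the ring gives a number 0.4 percentage points lower from compound 2 to compound 3 (within the scatter) and so provides the first reading at this position, which the earlier pair, differing only on an aromatic carbon, could not supply. With the 1H-1,2,4-triazol-1-yl group held in place, the sulfonyl version, which counts one more heavy atom and one more hydrogen-bond acceptor, cannot be told apart from the carbonyl version on this read-out, and both stay near the bottom of the scale. No evidence that would explain this result is available.

Open, from the compounds shown here alone, is whether a different group on this ring nitrogen, such as an acetyl, a benzyl or a methanesulfonyl group, would read any differently from these two. Also open is whether the same exchange of carbonyl for sulfonyl would read alike with 4-methylpiperazin-1-yl on the aromatic carbon, since the sulfonyl link is shown here only alongside 1H-1,2,4-triazol-1-yl.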